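Trading One Pyrazole Group for a Smaller One

This account rests on a few compounds, and the source may have more. Where it says the series, first, only, none or still open, it means among the compounds named here.

For the measured compounds named here, in a physicochemical assay for lipophilicity, using the shake flask method, in phosphate buffer, measured as octanol-water partition, with a stated time of 30 min, at pH 7.4 (a lower number here means a more polar compound, a higher number a more lipophilic compound), compound 1 `CN(C)C(=O)c1cc(-c2cnc(NCc3c(F)ccc4c3CCO4)c3cn[nH]c(=O)c23)n(C)n1` gives 2.1, the lower of the two numbers so far, while compound 2 `O=C(Nc1cnc(NCc2c(F)ccc3c2CCO3)n2cnnc12)c1ccccc1` gives 3, a gap beyond the usual scatter. Compound 3 `Cc1nn(C)cc1-c1cnc(NCc2c(F)ccc3c2CCO3)c2cn[nH]c(=O)c12` carries 1,3-dimethyl-1H-pyrazol-4-yl in place of 3-(dimethylcarbamoyl)-1-methyl-1H-pyrazol-5-yl on an aromatic carbon. Going by the values given here, no measured pair shows this change, so the expectation rests on the structures alone. With the dimethylcarbamoyl group gone, an upward step beyond the scatter is expected, estimated at a number 0.50 log units higher from compound 1 to compound 3 (beyond the scatter). For compound 3 the expected value is 2.6, with an estimated range of 2.1 to 3.1.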

Compound 3, distribution coefficient: 2.8
Compound 3: middle estimate off by 0.20 log units, on the low side; the measured number falls inside the stated range.
By their numbers in this assay, from the lowest: compound 1; then compounds 3 and 2 (each within the scatter of the next).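

For the compounds shown here, putting 1,3-dimethyl-1H-pyrazol-4-yl on this aromatic carbon in place of 3-(dimethylcarbamoyl)-1-methyl-1H-pyrazol-5-yl gives a number 0.70 log units higher from compound 1 to compound 3 (beyond the scatter) in this assay and provides the first step that can be read at this position. The entering group is the smaller of the two, with fewer heavy atoms and no oxygen. No measurement here explains the step.

Still open, on these data alone, is how much of the step belongs to losing the dimethylcarbamoyl group and how much to the pyrazole's changed point of attachment. Also open, as far as these compounds go, is how an amine or a carboxylic acid on this carbon would read.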